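Swapping One Ether Group on Compound 2

This account rests on a few compounds, and the source may have more. Where it says the series, first, only, none or still open, it means among the compounds named here.

Measured in a functional assay on HL-60 cells (Homo sapiens) for inhibition, read by CCK-8 assay, with a stated time of 48 h; on this read-out lower numbers stand for stronger inhibition and higher numbers for weaker inhibition:
- Compound 1 `O=[N+]([O-])c1ccc(NC(=S)NCCNS(=O)(=O)c2ccc(-c3ccccc3O[C@H]3CC[C@@H](O)CC3)s2)cc1`: > 50000 nM (a limit, not a number)
- Compound 2 `O=C(NCCNS(=O)(=O)c1ccc(-c2ccccc2O[C@H]2CC[C@@H](O)CC2)s1)Nc1cc(C(F)(F)F)cc(C(F)(F)F)c1`: 3100 nM
- Compound 3 `O=S(=O)(NCCNC(=S)Nc1ccc(Cl)cc1)c1ccc(-c2ccccc2OCc2ccccc2)s1`: > 50000 nM (a limit, not a number)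

Among these three results, compound 2 stands out as the only one that reads as an actual number. The other two results are recorded only as the limit of > 50000 nM in this assay, at which 2 of the 3 values shown sit.

Compound 4 `O=C(NCCNS(=O)(=O)c1ccc(-c2ccccc2OCc2ccccc2)s1)Nc1cc(C(F)(F)F)cc(C(F)(F)F)c1` has not yet been measured in this assay. It differs from compound 2 in one place: benzyl in place of 4-hydroxycyclohexyl on an oxygen on an aromatic ring. In words, this is benzyl in place of 4-hydroxycyclohexyl on an oxygen on an aromatic ring.

Among the measured compounds shown here, no measured pair isolates this change, so the expectation rests on thin ground. Compound 3 carries the same benzyl but also differs from compound 4 elsewhere, so its limit cannot be read as the effect of benzyl alone. Compound 4 shares everything outside the swapped group with compound 2, which gives 3100 nM, and that value is the natural starting point. No change beyond the usual scatter is therefore expected in this assay, although the uncertainty is wide. The expected step is a 1.1-fold higher number from compound 2 to compound 4 (0.05 log units; within the scatter). For compound 4 the estimated value is 3500 nM, with an expected range from 1200 nM to 12000 nM.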

Compound 4, half-maximal inhibitory concentration: 11400 nM
Compound 4: middle estimate off by 3.3-fold (0.51 log units), on the low side; the measured number falls inside the stated range.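

Among the compounds shown here, compounds 2 and 4 differ only in the group on the ring oxygen, so this pair gives the first direct reading of that place. In this assay, putting benzyl in place of 4-hydroxycyclohexyl gives a 3.7-fold higher number from compound 2 to compound 4 (0.57 log units; beyond the scatter), which shows that the group here affects inhibition, although the step is modest and compound 4 still gives a measurable number. Compound 1 and compound 3 add nothing to this comparison, since each differs from this pair in more than the ether group and each is recorded only as a limit, not a number: the limit of > 50000 nM in this assay, at which 2 of the 4 values shown sit.

The swap changes several things at once, replacing a non-aromatic ring with an aromatic one and removing the hydroxyl group and both defined stereocentres, so this single step cannot say which of these differences matters. A plain cyclohexyl group would keep the non-aromatic ring without the hydroxyl, and a 4-hydroxybenzyl group would keep the aromatic ring with a hydroxyl, so either could begin to pull these differences apart.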